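Trifluoromethyl Removal on a Shared Core: What to Expect

This account rests on a few compounds, and the source may have more. Where it says the series, first, only, none or still open, it means among the compounds named here.

Compound 1 `CC(=O)/C(=N\c1ccccc1Cl)NNc1ccccc1C(F)(F)F`: > 10000 nM; compound 2 `CC(=O)/C(=N\c1cccc(C)c1)NNc1ccccc1C(F)(F)F`: 1420 nM; compound 3 `CC(=O)/C(=N\c1ccccc1Cl)NNc1ccccc1`: > 10000 nM.

In an assay on isolated protein for binding affinity to corticotropin-releasing factor receptor 1 (Homo sapiens) (a lower number here means a stronger inhibitor, a higher number a weaker inhibitor), compound 1 gives > 10000 nM, which is a limit of the assay and not a number. Compound 2 gives 1420 nM in this assay. Compound 3 gives > 10000 nM in this assay, again a limit. The change 3-methylphenyl in place of 2-chlorophenyl on a double-bonded nitrogen yields an at least 7.0-fold lower number from compound 1 to compound 2 (0.84 log units; beyond the scatter). The change hydrogen in place of trifluoromethyl on an aromatic carbon yields a step that the two limits leave unreadable from compound 1 to compound 3, since both ends sit at the limit of > 10000 nM in this assay, at which 2 of the 3 values shown sit.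

Compound 4 `CC(=O)/C(=N\c1cccc(C)c1)NNc1ccccc1` differs from compound 2 by hydrogen in place of trifluoromethyl on an aromatic carbon, the same change as that from compound 1 to compound 3. Compound 4 is expected near 5000 nM, between 1500 nM and 20000 nM. The expected step of a 3.5-fold higher number from compound 2 to compound 4 (0.55 log units; beyond the scatter) rests on compound 2 at 1420 nM and on the unreadable a step that the two limits leave unreadable from compound 1 to compound 3, which leaves the direction of this change open.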

Compound 4, inhibition constant: 4710 nM
Compound 4: middle estimate off by 1.1-fold (0.03 log units), on the high side, within the range that was stated.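

On the core of compound 2, hydrogen in place of trifluoromethyl on an aromatic carbon gives a 3.3-fold higher number from compound 2 to compound 4 (0.52 log units; beyond the scatter) in this assay. The same change on the core of compound 1 cannot be read, because compound 1 and compound 3 both sit at a limit of the assay and not at a number: the limit of > 10000 nM in this assay, at which 2 of the 4 values shown sit. The series therefore offers a single readable instance of this change, which does not show whether its direction or size carries from one core to another.

The compounds shown leave open how other groups on that aromatic carbon would compare, such as a methoxy group, a nitrile or an amine. They also leave open whether any of these would behave alike on both cores.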